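Expected cytotoxicity of compound 4 after one ring swap

The compounds below may be only part of what the source reports. "The series", "measured", "known", "first", "only" and "open" are said of these compounds alone.

Three compounds sharing one core were tested in an ADME assay on HEK293 cells (Homo sapiens) for cytotoxicity, with a stated time of 72 h; on this read-out higher numbers stand for an effect only at larger amounts of compound and lower numbers for an effect already at smaller amounts. In this assay compound 1 `Cc1cc(NC(=O)Nc2ccc(C)c(Cl)c2)c2ccccc2n1` shows no effect up to the limit of the assay, reported as > 25000 nM. Compound 2 `Cc1cc(NC(=O)Nc2ccc(C(=O)O)cc2)c2ccccc2n1` likewise reaches only that limit, > 25000 nM. Compound 3 `Cc1cc(NC(=O)Nc2ncccc2C)c2ccccc2n1` stands at the same limit, > 25000 nM, so its number is not known, only that it lies beyond the range tested; this holds for every value shown here, (the limit of > 25000 nM in this assay, at which 3 of the 3 values shown sit). Compound 4 `Cc1ccc(NC(=O)Nc2cc(C)nc3ccccc23)cc1` has not been measured yet. It differs from compound 3 in one place: 4-methylphenyl in place of 3-methylpyridin-2-yl on an amide-type nitrogen. For the measured compounds named here, since no pair of measured compounds differs in only one place, no measured step is available, and how far such a swap moves the read-out cannot be read from these data. Because compound 3 gives only the limit > 25000 nM, the expected step is a number no higher from compound 3 to compound 4 (the limit leaves the size open), none beyond the scatter. Compound 4 is therefore estimated at 25000 nM, within 8000 nM to 60000 nM, most likely reported as a limit once more.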

Compound 4, half-maximal effective concentration: > 25000 nM
Compound 4 gave a limit, no number; the forecaster's own chance of this, stated with the estimate: 80%; the middle value lies on the limit itself.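

The steps from compound 1, compound 2 and compound 3 to compound 4 cannot be read, because in this assay each result is a limit and not a number: the limit of > 25000 nM in this assay, at which 4 of the 4 values shown sit.

The compounds shown leave open how far any of these changes on the shared core moves cytotoxicity.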